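Swapping the aryl group on the piperazine nitrogen

The source may report more compounds than this note shows. Statements on the series, on what has been measured and on what is new or still open speak of the compounds shown alone.

Compound 1 `Nc1scc(CN2CCN(c3ccc(F)cc3Cl)CC2)c1C(=O)c1ccc(Cl)cc1` gives 0%
Compound 2 `Nc1scc(CN2CCN(c3ccc([N+](=O)[O-])cc3)CC2)c1C(=O)c1ccc(Cl)cc1` gives 2%
Compound 3 `Nc1scc(CN2CCN(c3ccc(F)cc3F)CC2)c1C(=O)c1ccc(Cl)cc1` gives 0%

All three compounds were tested in an assay on CHO cells for displacement of a labelled ligand from adenosine receptor A3 (Homo sapiens), read by scintillation counting, with a stated time of 120 min, tested at 10 uM (on this read-out higher numbers stand for more inhibition at the one concentration tested (going by the name of the read-out) and lower numbers for less inhibition), and all three show essentially no displacement at the single concentration used. Among the compounds with values here, compound 2 sits among them with a number 2 percentage points higher from compound 1 to compound 2 (within the scatter) and a number 2 percentage points lower from compound 2 to compound 3 (within the scatter), so the three numbers lie within the scatter of one another and no compound can be set apart from the others.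

Compound 4 `Nc1scc(CN2CCN(c3c(F)cccc3F)CC2)c1C(=O)c1ccc(Cl)cc1` has not yet been measured. It differs from compound 2 in one place: 2,6-difluorophenyl in place of 4-nitrophenyl on an amine nitrogen in a ring. Within the data shown here, the steps that bear on this change are those that also replace the aryl group on the ring nitrogen, a number 2 percentage points higher from compound 1 to compound 2 (within the scatter) and a number 2 percentage points lower from compound 2 to compound 3 (within the scatter), and neither moved the read-out beyond the scatter. No listed step gives any reason to expect a different outcome for compound 4, so no change beyond the scatter is expected in this assay. Compound 4 is therefore estimated at 1%, within a range from -6% to 10%, which means an expected step of a number 1 percentage points lower from compound 2 to compound 4 (within the scatter).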

Compound 4, a percentage reported as inhibition, at one concentration (the size of the read-out at that concentration, not a potency): 4%
The estimate for compound 4 lay 3 percentage points below the measured number; the measured number falls inside the stated range.
By their numbers in this assay, from the lowest: compounds 1, 3, 2 and 4 (each within the scatter of the next).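

In this assay, 2,6-difluorophenyl on the amine nitrogen in the ring is a further aryl replacement that stays within the scatter, whether it takes the place of 4-nitrophenyl (a number 2 percentage points higher from compound 2 to compound 4 (within the scatter)), 2,4-difluorophenyl (a number 4 percentage points higher from compound 3 to compound 4 (within the scatter)) or 2-chloro-4-fluorophenyl (a number 4 percentage points higher from compound 1 to compound 4 (within the scatter)). Two things are new: moving a fluorine around the phenyl ring, as between compound 3 and compound 4, gives no readable change, and neither does exchanging 4-nitrophenyl, which has hydrogen-bond acceptors, for a group with none. No measured evidence is available to explain these results.

As far as these compounds go, whether a benzyl group, a pyridine ring or a simple alkyl chain on that nitrogen would give real displacement remains open. So does whether changing the shared core, rather than this aryl group, would do so.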